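A few compounds are considered here, and "the series" means these few. Any claim that something is new, unique, unknown or untested is made for them only; others in the source may bear on it.

Measured compounds in this study:

compound 1, `CCN(c1ccc(C#N)c(Cl)c1)c1cc(-c2ccccc2)ccc1C`: "not determined" (no result reported)
compound 2, `CCN(c1cccc(-n2ccnc2)c1)c1ccc(C#N)c(Cl)c1`: > 30000 nM
compound 3, `CCN(c1ccc(C#N)c(C(F)(F)F)c1)c1cc(-n2ccnc2)ccc1C`: > 30000 nM

In a functional assay on PC-3 cells (Homo sapiens) for antiproliferative activity, read by CCK-8 assay, with a stated time of 6 days (a lower number here means a stronger inhibitor, a higher number a weaker inhibitor), compound 1 stands at "not determined" (no result reported), so no number places it on the scale. Compound 2 reaches only a limit of the assay, > 30000 nM. Compound 3 also reaches only a limit, > 30000 nM. The one firm point in the set is therefore (the limit of > 30000 nM in this assay, at which 2 of the 3 values shown sit); nothing shows how compound 1 relates to it.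

Compound 4, `CCN(c1ccc(C#N)c(Cl)c1)c1cc(-n2cccn2)ccc1C`, has not yet been measured. It differs from compound 1 by 1H-pyrazol-1-yl in place of phenyl on an aromatic carbon. For the measured compounds named here, no step between measured compounds exists here, so the size of the step from compound 1 to compound 4 in this assay cannot be taken from the data; with compound 1 undetermined, only the limits of compound 2 and compound 3 give a bearing. Given that both of those sit at the limit, the account leans toward weak activity, though a measurable number is possible. Compound 4 is expected to give about 20000 nM, with a range from 3000 nM to 30000 nM.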

Compound 4, half-maximal inhibitory concentration: 15700 nM
The estimate for compound 4 lay 1.3-fold (0.11 log units) above the measured number, and the stated range covers the measured number.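

No step can be read from the result for compound 4: compound 1 stands at "not determined" (no result reported), so the pair gives no comparison. The compounds shown leave open what phenyl giving way to 1H-pyrazol-1-yl does to the value in this assay.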